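Toward a Propyl Analogue of an Inactive Acid

The compounds below may be only part of what the source reports. "The series", "measured", "known", "first", "only" and "open" are said of these compounds alone.

Compound 1, `CCN(Cc1cccs1)C(=O)COc1ccc(C(=O)O)cc1`: "not active" (no number reported)
Compound 2, `Cc1ccc(OCC(=O)N(CCCO)Cc2cccs2)cc1`: 3000 nM

In an assay on HEK293 cells for agonist activity at transient receptor potential cation channel subfamily M member 8 (Homo sapiens), read by fluorescence and calcium flux, with a stated time of 15 min (on this read-out lower numbers stand for an effect already at smaller amounts and higher numbers for an effect only at larger amounts of compound), compound 1 gives "not active" (no number reported), so no number stands for it and it cannot be placed on the scale. Among the compounds with values here, compound 2 is the only compound with a value, 3000 nM in this assay. Compound 3 `CCCc1ccc(OCC(=O)N(CC)Cc2cccs2)cc1` differs from compound 1 in one place: propyl in place of carboxy on an aromatic carbon. Within the data shown here, no measured pair shows a step of this kind, so its size is open; since compound 1 gave no number, any reported value for compound 3 would count as a gain in this assay. Compound 3 is expected near 1500 nM, between 300 nM and 10000 nM.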

Compound 3, half-maximal effective concentration: 1810 nM
The estimate for compound 3 lay 1.2-fold (0.08 log units) below the measured number; measured number inside the range.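

Within the data shown here, compound 1 carries no number in this assay, and no step to compound 3 can be read from it. The compounds shown leave open how large a change carboxy to propyl brings. Nothing offered here explains the result.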